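Salicylanilide series: amine substituent change and cytotoxicity notes

A few compounds are considered here, and "the series" means these few. Any claim that something is new, unique, unknown or untested is made for them only; others in the source may bear on it.

Measured so far:
compound 1 `O=C(Nc1ccc(NCC2CCCC2)cc1Cl)c1cc(Cl)ccc1O`: 141000 nM
compound 2 `O=C(Nc1ccc(NCc2ccc(F)cc2)cc1Cl)c1cc(Cl)ccc1O`: "not determined" (no result reported)
compound 3 `O=C(Nc1ccc(NCC2CCNCC2)cc1Cl)c1cc(Cl)ccc1O`: "not determined" (no result reported)

In an ADME assay on A549 cells (Homo sapiens) for cytotoxicity, read by LDH release, with a stated time of 15 h (on this read-out higher numbers stand for lower toxicity in this test and lower numbers for higher toxicity in this test), compound 1 gives 141000 nM. Compound 2 in this assay gives "not determined" (no result reported). For the measured compounds named here, compound 3 in this assay gives "not determined" (no result reported), so compound 3 stands without a single number, one of two such entries in the set, and compound 1 is the only compound with a numeric result.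

Compound 4 `CCCCCCC(C)Nc1ccc(NC(=O)c2cc(Cl)ccc2O)c(Cl)c1` differs from compound 3 by 1-methylheptyl in place of (piperidin-4-yl)methyl on a nitrogen on an aromatic ring. Going by the values given here, no step between measured compounds is at hand, and compound 3 carries no number, so the step from compound 3 to compound 4 in this assay cannot be anchored in either size or direction; any expectation rests on compound 1 alone. Compound 1, a close relative of the same core, sits at 141000 nM, a weakly toxic reading in this assay, and compound 4 is expected to land in the same region, with wide uncertainty. Compound 4 is therefore estimated at 80000 nM, within a range from 20000 nM to 300000 nM.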

Compound 4, half-maximal cytotoxic concentration: 18600 nM
Compound 4: middle estimate off by 4.3-fold (0.63 log units), on the high side; the whole stated range lies above it.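

In this assay, for the compounds shown here, 1-methylheptyl in place of cyclopentylmethyl on a nitrogen on an aromatic ring gives a 7.6-fold lower number from compound 1 to compound 4 (0.88 log units; beyond the scatter), the first readable step in the set and one beyond the usual scatter. The substituent on this nitrogen therefore affects the reading on the shared core, with the open-chain 1-methylheptyl pair member the more toxic in this test, although this rests on one pair only. No available data account for the step.

Steps involving compound 2 or compound 3 cannot be read. Left open is whether the lower number follows from the branching, the chain length or the loss of the ring, and how a longer unbranched chain or a carboxylic acid on the side chain would read.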